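Inverting both ring stereocentres of compound 3

The compounds below may be only part of what the source reports. "The series", "measured", "known", "first", "only" and "open" are said of these compounds alone.

Compound 3 `CO[C@H]1CC[C@@H](Nc2cc(NCc3cnccc3C(F)(F)F)ncc2C#N)CC1` gives the lowest number of the three measured in an assay on isolated protein for inhibition of protein kinase C theta type (Homo sapiens), read by TR-FRET, with a stated time of 2 h (a lower number here means a stronger inhibitor, a higher number a weaker inhibitor), at 58 nM; compound 1 `N#Cc1cnc(NCc2cnccc2C(F)(F)F)cc1N[C@H]1C[C@@H](O)C1` gives 500 nM and compound 2 `N#Cc1cnc(NCc2cnccc2C(F)(F)F)cc1NC[C@H]1C[C@H](O)C1` gives 700 nM, with an 8.6-fold lower number from compound 1 to compound 3 (0.94 log units; beyond the scatter) and a 12-fold lower number from compound 2 to compound 3 (1.08 log units; beyond the scatter). Compound 4 `CO[C@H]1CC[C@H](Nc2cc(NCc3cnccc3C(F)(F)F)ncc2C#N)CC1` keeps every atom and bond of compound 3: the two compounds have the same atoms and bonds and differ only in configuration as drawn: 2 of 2 stereo elements differ (all stereocentres are inverted: mirror images); a stereocentre at a saturated ring carbon is drawn s in compound 3 and r in compound 4; a stereocentre at a saturated ring carbon is drawn s in compound 3 and r in compound 4. Among the compounds with values here, none of the measured steps changes configuration alone, so no step bears directly on this change; the measured steps all swap groups on the ring nitrogen. The expectation is therefore uncertain, with a modest weakening as the more likely outcome, a 2.1-fold higher number from compound 3 to compound 4 (0.32 log units; beyond the scatter), and compound 4 is estimated at 120 nM, within a range of 30 nM to 500 nM in this assay.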

Compound 4, half-maximal inhibitory concentration: 1100 nM
The estimate for compound 4 lay 9.2-fold (0.96 log units) below the measured number; the measured number lies above the stated range.
By their numbers in this assay, from the lowest: compound 3; then compounds 1, 2 and 4 (each within the scatter of the next, the first and the last beyond it).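

The 4-methoxycyclohexyl group does not help by its presence alone, since its drawn configuration decides the result, with a 19-fold higher number from compound 3 to compound 4 (1.28 log units; beyond the scatter). This loss can be assigned to configuration because nothing else changes: the fact that compounds 3 and 4 differ only in the configuration as drawn. The advantage of compound 3 over the cyclobutyl compounds also disappears with this inversion, as the steps are a 1.6-fold higher number from compound 2 to compound 4 (0.20 log units; within the scatter) and a 2.2-fold higher number from compound 1 to compound 4 (0.34 log units; beyond the scatter).

As far as these compounds go, whether configuration matters as much when the methoxy group gives way to a hydroxy group or an amine remains open.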